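The compounds below may be only part of what the source reports. "The series", "measured", "known", "first", "only" and "open" are said of these compounds alone.

Measured so far:
compound 1 `O=C(O)CCc1ccc(C#CC2CC2)cc1`, 5010 nM in a functional assay on 1321-N1 cells for agonist activity at Free fatty acid receptor 1 (Homo sapiens), read by calcium flux, with a stated time of 0.4 s; a lower number here means that less compound is needed, a higher number that more compound is needed for the effect
compound 2 `C/C(C#Cc1ccc(CCC(=O)O)c(F)c1)=C/CO`, 427 nM
compound 3 `O=C(O)CCc1ccc(C#CC2CCCC2)cc1`, 490 nM

Compound 2 gives the lowest number of the three, but compound 3 sits within the scatter of it; only compound 1 lies clearly higher. Within the data shown here, the one step that can be read from these compounds is a 10-fold lower number from compound 1 to compound 3 (1.01 log units; beyond the scatter), a change of ring size on the triple-bonded carbon.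

Compound 4 `C=C(C)C#Cc1ccc(CCC(=O)O)c(F)c1` differs from compound 2 in one place: 1-methylethenyl in place of 3-hydroxy-1-methylprop-1-en-1-yl on a triple-bonded carbon. The measured step concerns a different kind of change and the hydroxyl group is removed here without any precedent in the series. Compound 4 is expected to need somewhat more compound, a step of a 3.5-fold higher number from compound 2 to compound 4 (0.55 log units; beyond the scatter), with an estimate of 1500 nM and a range from 500 nM to 4500 nM.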

Compound 4, half-maximal effective concentration: 81.3 nM
Compound 4: middle estimate off by 18-fold (1.27 log units), on the high side; the measured number lies below the stated range.
By their numbers in this assay, from the lowest: compound 4; then compounds 2 and 3 (each within the scatter of the next); then compound 1.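

In this assay the change to 1-methylethenyl on the triple-bonded carbon gives a 5.3-fold lower number from compound 2 to compound 4 (0.72 log units; beyond the scatter) and so shows that the hydroxyl of 3-hydroxy-1-methylprop-1-en-1-yl is not required at this position. The earlier step varied only ring size here, whereas this one shows that a small open-chain group without hydrogen-bond donors or acceptors can carry a low number. No measurement on hand explains the change. The hydroxyl and the chain length change together, leaving their separate contributions open. A methoxy group or an amine on the same chain would help tell them apart.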